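The source may report more compounds than this note shows. Statements on the series, on what has been measured and on what is new or still open speak of the compounds shown alone.

The measured compounds in this set:

compound 1, `CCC(=O)N1C[C@@H](O[C@H](C)c2cc(C(F)(F)F)cc(C(F)(F)F)c2)[C@H](c2ccc(F)cc2)C1`: 0.09 nM
compound 2, `CC(C)C(=O)N1C[C@@H](O[C@H](C)c2cc(C(F)(F)F)cc(C(F)(F)F)c2)[C@H](c2ccc(F)cc2)C1`: 0.15 nM

In an assay on CHO cells for displacement of a labelled ligand from Substance-P receptor (Homo sapiens) (on this read-out lower numbers stand for stronger inhibition and higher numbers for weaker inhibition), compound 1 gives 0.09 nM, and compound 2 gives 0.15 nM. Going by the values given here, the one measured step, a 1.7-fold higher number from compound 1 to compound 2 (0.22 log units; within the scatter), exchanges a hydrogen for a methyl on the saturated chain carbon bound to the carbonyl. Compound 2 thus stands at the higher of the two numbers shown, with compound 1 nearest, the gap between them within the scatter.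

Compound 3, `CCNC(=O)N1C[C@@H](O[C@H](C)c2cc(C(F)(F)F)cc(C(F)(F)F)c2)[C@H](c2ccc(F)cc2)C1`, differs from compound 2 by ethylamino in place of isopropyl on a carbonyl carbon. Among the compounds with values here, the measured step bears on it only in part: it shows that changing the alkyl group on this carbonyl moves this assay little, but no measured pair puts a nitrogen with a hydrogen-bond donor on that carbonyl, so the direction of the new change is not anchored by the data. A modest step is therefore expected, most likely toward a higher number, with a 2.3-fold higher number from compound 2 to compound 3 (0.37 log units; beyond the scatter) as the expected shift. Compound 3 is estimated at 0.35 nM, within a range of 0.08 nM to 1.5 nM.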

Compound 3, half-maximal inhibitory concentration: 0.1 nM
The estimate for compound 3 lay 3.5-fold (0.54 log units) above the measured number; low and high end bracket the measured number.
By their numbers in this assay, from the lowest: compounds 1, 3 and 2 (each within the scatter of the next).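

In this assay, ethylamino in place of isopropyl on the carbonyl carbon gives a 1.5-fold lower number from compound 2 to compound 3 (0.18 log units; within the scatter) and ethylamino in place of ethyl on the same carbon gives a 1.1-fold higher number from compound 1 to compound 3 (0.05 log units; within the scatter) as the second reading of this change. The earlier pair had only exchanged one alkyl group for another, whereas these steps show that a chain bringing in a nitrogen and a hydrogen-bond donor can stand on this carbonyl carbon, whose other neighbour is the amide-type nitrogen in a ring, without any step leaving the scatter, so that all three compounds remain indistinguishable in this read-out. No supporting information is available to account for this outcome.

The compounds shown leave open whether the amide hydrogen of the ethylamino group matters at all, a question that a dimethylamino group on the same carbonyl carbon would bear on directly. They also leave open how much larger the group on this carbonyl carbon can become, for example a longer chain such as hexyl or a ring such as morpholine, before the number moves beyond the scatter.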